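Amide nitrogen substituent change on the shared core

The source may report more compounds than this note shows. Statements on the series, on what has been measured and on what is new or still open speak of the compounds shown alone.

Compound 1 `COc1cccc(CNC(=O)c2nc(Br)c3cccnc3c2N[C@H]2CC[C@H](N)CC2)c1` is the only one of the three measured compounds that returns a number: in a functional assay on HCT-116 cells (Homo sapiens) for cytotoxicity, read by MTT assay, with a stated time of 72 h (a lower number here means a stronger inhibitor, a higher number a weaker inhibitor), compound 1 gives 6000 nM. Compound 2 `CNc1c(C(=O)NCc2ccc(F)cc2)nc(Br)c2cccnc12` reaches only the assay limit, > 20000 nM in this assay. Compound 3 `O=C(NCc1ccc(F)cc1)c1nc(Br)c2cccnc2c1NCc1ccccc1` likewise rests at the limit, giving > 20000 nM in this assay. Among the compounds with values here, the single measured step, a step that the two limits leave unreadable from compound 2 to compound 3, therefore cannot be read, since both of its ends sit on (the limit of > 20000 nM in this assay, at which 2 of the 3 values shown sit). Compound 4 `N[C@H]1CC[C@H](Nc2c(C(=O)Nc3ccccc3)nc(Br)c3cccnc23)CC1` differs from compound 1 at the amide-type nitrogen: phenyl in place of 3-methoxybenzyl on an amide-type nitrogen. Within the data shown here, no measured step touches this position; the one step seen concerns a different nitrogen and is unreadable in any case. Compounds 2 and 3 also differ from compound 1 in more than one place, so neither offers an anchor for this change. There is thus no measured ground to expect a step in either direction beyond the scatter. The expected step is a 1.3-fold higher number from compound 1 to compound 4 (0.12 log units; within the scatter), a change that stays within the usual scatter. The estimate in this assay for compound 4 is 8000 nM, with a range from 2500 nM to 25000 nM; a return of only a limit cannot be excluded.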

Compound 4, half-maximal inhibitory concentration: 2000 nM
Estimate against measurement, compound 4: 4.0-fold (0.60 log units) above; measured number below the stated range.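

In this assay the amide-type nitrogen now carries a readable step, a 3.0-fold lower number from compound 1 to compound 4 (0.48 log units; beyond the scatter), with phenyl in place of 3-methoxybenzyl, so the number at this position does respond to the group it carries. The change takes out 9 heavy atoms and puts in 6, and the smaller phenyl group gives the lower number in this one pair, which shows that the 3-methoxybenzyl group is not required for the activity seen with compound 1. Within the data shown here, the earlier compounds could not show this, since the only step among them cannot be read and neither compound 2 nor compound 3 differs from compound 1 in one place only, with both resting at a limit of the assay: the limit of > 20000 nM in this assay, at which 2 of the 4 values shown sit.

Nothing shown gives a cause for the step, and a single pair sets no trend for this position. On these data alone, compound 1 and compound 4 differ in both the methoxy group and the carbon that links the ring to the nitrogen, so it stays open which of the two carries the step, and a plain benzyl group or a 2-phenylethyl chain on this nitrogen, or an amine on the phenyl ring, would be needed to place it.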